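Cytotoxicity notes: tosyloxy in place of aminopropylamino

A few compounds are considered here, and "the series" means these few. Any claim that something is new, unique, unknown or untested is made for them only; others in the source may bear on it.

Measured compounds:
compound 1, `NCCCNc1c(C(=O)NCc2ccc(F)cc2)nc(Br)c2cccnc12` — "not determined" (no result reported)
compound 2, `O=CNCCCCCCNc1nc(C(=O)NCc2ccc(F)cc2)c(O)c2ncccc12` — 199000 nM

Two compounds of the series have been put through a toxicity assay on C8166 cells (Homo sapiens) for cytotoxicity, read by MTT assay, with a stated time of 72 h; on this read-out lower numbers stand for higher toxicity in this test and higher numbers for lower toxicity in this test. Among the compounds with values here, compound 1 returned no number in this assay, so it has no standing on the scale; compound 2 gives 199000 nM in this assay, and this is the only value available for the series. Compound 3, `Cc1ccc(S(=O)(=O)Oc2c(C(=O)NCc3ccc(F)cc3)nc(Br)c3cccnc23)cc1`, is the next compound to go in. It differs from compound 1 in one place: ((4-methylphenyl)sulfonyl)oxy in place of (3-aminopropyl)amino on an aromatic carbon. Within the data shown here, with no number for compound 1 and no step between measured compounds, the direction of the change cannot be read from the data; the size of the step in this assay is unknown, and a shift in either direction or none beyond the scatter is possible. Among the measured compounds shown here, the only anchor is compound 2. Compound 3 is therefore expected to land near that region, estimated at 100000 nM in this assay, with a range from 20000 nM to 300000 nM.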

Compound 3, half-maximal cytotoxic concentration: 31000 nM
Compound 3: middle estimate off by 3.2-fold (0.51 log units), on the high side; low and high end bracket the measured number.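

No step can be read between compound 1 and compound 3: in this assay compound 1 gives "not determined" (no result reported) and compound 3 gives 31000 nM with no partner number to set against it. On these data alone, what replacing (3-aminopropyl)amino with ((4-methylphenyl)sulfonyl)oxy does to the cytotoxicity read-out stays open. No available evidence bears on the result for compound 3.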